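Carbonyl substituent change from compound 2 to compound 3

A few compounds are considered here, and "the series" means these few. Any claim that something is new, unique, unknown or untested is made for them only; others in the source may bear on it.

- compound 1 `O=C(c1ccc(Cl)cc1)N1CCC(NS(=O)(=O)c2cc(S(=O)(=O)c3ccccc3)ccc2C(F)(F)F)CC1`: 3100 nM
- compound 2 `O=C(c1ccccn1)N1CCC(NS(=O)(=O)c2cc(S(=O)(=O)c3ccccc3)ccc2C(F)(F)F)CC1`: 100000 nM

Going by the values given here, in a physicochemical assay for solubility (a higher number here means a more soluble compound, a lower number a less soluble compound), compound 2 stands at 100000 nM, the higher of the two numbers so far, with compound 1 beyond the scatter beneath it.

Compound 3 `CN(C)c1ccc(C(=O)N2CCC(NS(=O)(=O)c3cc(S(=O)(=O)c4ccccc4)ccc3C(F)(F)F)CC2)cn1` keeps the core of compound 2 and differs at one place: 6-(dimethylamino)pyridin-3-yl in place of pyridin-2-yl on a carbonyl carbon. In short, 6-(dimethylamino)pyridin-3-yl stands in place of pyridin-2-yl on a carbonyl carbon.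

Among the compounds with values here, one measured step bears on this place: a 32-fold higher number from compound 1 to compound 2 (1.51 log units; beyond the scatter). It is large and beyond the scatter, and it came with pyridin-2-yl in place of 4-chlorophenyl. Compound 3 gives up that same pyridin-2-yl, though an aromatic ring with one hetero atom remains. Within the data shown here, no measured compound carries the entering group, so this single step is weak guidance and the range stays wide.

A partial return towards compound 1, at 3100 nM, is expected, with a lower number in this assay and a smaller change than the measured step. The expected step is a 5.0-fold lower number from compound 2 to compound 3 (0.70 log units; beyond the scatter). For compound 3 the estimated value is 20000 nM, with an expected range of 4000 nM to 100000 nM.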

Compound 3, solubility: 12500 nM
For compound 3 the middle estimate is 1.6-fold (0.20 log units) above the measured one; measured number inside the range.
By their numbers in this assay, from the lowest: compound 1; then compound 3; then compound 2.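

In this assay, the carbonyl substituent does not behave as a simple choice between a high and a low outcome: 6-(dimethylamino)pyridin-3-yl in place of pyridin-2-yl gives an 8.0-fold lower number from compound 2 to compound 3 (0.90 log units; beyond the scatter), while the same group in place of 4-chlorophenyl gives a 4.0-fold higher number from compound 1 to compound 3 (0.61 log units; beyond the scatter). The new group therefore places compound 3 between the two earlier compounds, with both steps beyond the scatter, and keeping a six-membered aromatic ring with one hetero atom is not enough to retain the number of compound 2. No supporting measurement accompanies these numbers, so they describe the change without accounting for it.

The change from compound 2 to compound 3 alters both the point at which the ring meets the carbonyl carbon and the presence of the dimethylamino group, so the compounds shown leave open how the step divides between the two, a question that a plain pyridin-3-yl at this place would bear on. Also open, on these data alone, is whether the trend extends to other substituents on the pyridine ring, such as a methoxy group, a morpholine or a carboxylic acid.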